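The source may report more compounds than this note shows. Statements on the series, on what has been measured and on what is new or still open speak of the compounds shown alone.

In a toxicity assay on NIH3T3 cells (Mus musculus) for cytotoxicity, read by resazurin assay (on this read-out lower numbers stand for an effect already at smaller amounts and higher numbers for an effect only at larger amounts of compound), compound 1 `COC(=O)c1ccc(NCc2cncn2Cc2ccccc2Cl)cc1-c1ccccc1` gives 10000 nM. Compound 2 `COC(=O)c1ccc(NCc2cncn2Cc2ccccc2OC)cc1-c1ccccc1` differs from it only in the group on the saturated chain carbon bound to an aromatic nitrogen, and for compound 2 this assay reports "not determined" (no result reported), so compound 2 stands without a single number here. Compound 3 `COC(=O)c1ccc(NCc2cncn2Cc2ccc(C)cc2)cc1-c1ccccc1` is reached from compound 2 by one change: 4-methylphenyl in place of 2-methoxyphenyl on a saturated chain carbon bound to an aromatic nitrogen. Without a measured step for this kind of swap, no shift beyond the usual scatter is expected in this assay. Compound 3 is expected to give about 10000 nM, estimated between 3000 nM and 30000 nM.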

Compound 3, half-maximal effective concentration: 50000 nM
Beside the measured number, compound 3's estimate is 5.0-fold (0.70 log units) below it; measured number outside the range, above it.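

In this assay the swap of 2-chlorophenyl for 4-methylphenyl gives a 5.0-fold higher number from compound 1 to compound 3 (0.70 log units; beyond the scatter) and so shows that the group on a saturated chain carbon bound to an aromatic nitrogen can move this number beyond the usual scatter. The change from compound 2 to compound 3 itself cannot be read, as compound 2 has no number.

From the compounds shown here alone, what 4-chlorophenyl or 2-methylphenyl would give at this place stays open, so the step cannot yet be tied to the kind of group or to its place on the ring. No measurement shown bears on why the number moved.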